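This account rests on a few compounds, and the source may have more. Where it says the series, first, only, none or still open, it means among the compounds named here.

Compound 1 `Brc1ccc(Nc2nc(-n3cnc4ccccc43)cs2)cc1` and compound 2 `Cc1nc2ccccc2n1-c1csc(Nc2ccc(Br)cc2)n1` share a core and differ by one change, (methyl in place of hydrogen on an aromatic carbon). In a functional assay on RKO cells (Homo sapiens) for cytotoxicity, read by resazurin assay, with a stated time of 72 h (on this read-out higher numbers stand for weaker inhibition and lower numbers for stronger inhibition), compound 1 gives only a limit of the assay, > 100000 nM. In this assay compound 2 gives 60000 nM. The measured step is an at least 1.6-fold lower number from compound 1 to compound 2 (0.22 log units; that floor lies within the scatter), and it rests on (the limit of > 100000 nM in this assay, at which 2 of the 3 values shown sit), so its true size is open.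

Compound 3 `Cc1nccn1-c1csc(Nc2ccccc2)n1` carries a smaller core; the difference between the two cores is not broken down here. In this assay compound 3 gives only a limit, > 100000 nM.

Compound 4 `Cc1ccc(Nc2nc(-n3ccnc3C)cs2)cc1` is not yet measured. It arises from compound 3 by the same kind of change, (methyl in place of hydrogen on an aromatic carbon), but the place differs: here the methyl sits on an aromatic carbon of a six-membered aromatic ring of carbon only, para to a large group, whereas in compound 2 it sits on a five-membered aromatic ring with 2 nitrogen, between two ring nitrogen atoms.

From compound 3 a step of an at least 1.1-fold lower number from compound 3 to compound 4 (0.04 log units; that floor lies within the scatter) is expected, about the size seen from compound 1 to compound 2, and a second limit is quite possible. Compound 4 is therefore estimated at 90000 nM in this assay, between 30000 nM and 300000 nM.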

Compound 4, half-maximal inhibitory concentration: > 100000 nM
Compound 4: a limit, no number; the forecaster's own chance of this, stated with the estimate: 55%; middle value at least 1.1-fold (0.04 log units) away from the limit.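

No step can be read from compound 3 to compound 4, since both give only a limit: the limit of > 100000 nM in this assay, at which 3 of the 4 values shown sit.

The compounds shown leave open whether methyl in place of hydrogen on the six-membered aromatic ring of carbon only changes the read-out at all in this assay.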